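The compounds below may be only part of what the source reports. "The series", "measured", "known", "first", "only" and "open" are said of these compounds alone.

Within the data shown here, in a functional assay on A2780 ADR cells (Homo sapiens) for cytotoxicity, read by MTT assay, with a stated time of 24 h (a higher number here means a weaker inhibitor, a lower number a stronger inhibitor), compound 1 `CCCCC[C@H](C[C@@H](O)C[C@H]1CC=CC(=O)O1)OC` gives 18100 nM and holds the lower of the two numbers so far, while compound 2 `CCCCC[C@@H](C[C@H](O)C[C@H]1CC=CC(=O)O1)OC` gives 48000 nM there. Among the measured compounds shown here, the only measured step is a 2.7-fold higher number from compound 1 to compound 2 (0.42 log units; beyond the scatter) and it concerns the fact that compounds 1 and 2 differ only in the configuration as drawn so no removal of a group has yet been tested. Compound 3 `CCCCC[C@H](CCC[C@H]1CC=CC(=O)O1)OC` differs from compound 1 by hydrogen in place of hydroxy on a saturated chain carbon bound to two saturated chain carbons with hydrogen in place of hydroxy on a saturated chain carbon bound to two saturated chain carbons. In this assay the expected change is small, leaning slightly upward and no larger than that modest step, with an estimated 1.4-fold higher number from compound 1 to compound 3 (0.14 log units; within the scatter) for this swap. Compound 3 is expected at about 25000 nM with an estimated range from 8000 nM to 75000 nM in this test.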

Compound 3, half-maximal inhibitory concentration: 12200 nM
The estimate for compound 3 lay 2.0-fold (0.31 log units) above the measured number; measured number inside the range.
By their numbers in this assay, from the lowest: compounds 3 and 1 (each within the scatter of the next); then compound 2.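

Replacing the hydroxy on this saturated chain carbon bound to two saturated chain carbons with hydrogen in this assay gives a 1.5-fold lower number from compound 1 to compound 3 (0.17 log units; within the scatter). Compound 1 and compound 2 showed only a change of configuration, whereas this step shows that the activity in this assay does not depend measurably on the hydroxy itself. Nothing measured here gives a reason for this result. As far as these compounds go, whether an amine or a carboxylic acid at this carbon would leave the number equally unchanged stays open. So does the effect of a longer chain.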